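Methoxycarbonyl in Place of Methyl at the Assay Limit

The source may report more compounds than this note shows. Statements on the series, on what has been measured and on what is new or still open speak of the compounds shown alone.

In a functional assay on EBC-1 cells (Homo sapiens) for inhibition, read by sulforhodamine B assay, with a stated time of 72 h (on this read-out higher numbers stand for weaker inhibition and lower numbers for stronger inhibition), compound 1 `COc1ccc2c(OCCn3c(=O)oc4cc(C)ccc43)ccnc2c1` gives > 500 nM, which is a limit and not a number. Compound 2 `COc1ccc2c(OCCn3c(=O)oc4ccc(C)cc43)ccnc2c1` gives > 500 nM, which is also a limit. Among the measured compounds shown here, compound 2 therefore stands with no number of its own, and the series so far shows (the limit of > 500 nM in this assay, at which 2 of the 2 values shown sit). Compound 3 `COC(=O)c1ccc2oc(=O)n(CCOc3ccnc4cc(OC)ccc34)c2c1` differs from compound 2 by one change, methoxycarbonyl in place of methyl on an aromatic carbon. For the measured compounds named here, no measured step is available as a guide, so only weak inhibition is expected to persist in this assay, and the expected step that the limit leaves unreadable from compound 2 to compound 3 is none beyond the scatter. For compound 3 the estimate is 1000 nM, with an expected range from 300 nM to 5000 nM.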

Compound 3, half-maximal inhibitory concentration: > 500 nM
Compound 3: no number, only a limit; the forecaster's own chance of this, stated with the estimate: 75%; the middle value does not contradict the limit.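

Among the compounds shown here, compound 2 and compound 3 both sit at a limit in this assay, so no step between them can be read. The compounds shown leave open whether methoxycarbonyl in place of methyl on an aromatic carbon changes inhibition at all: the limit of > 500 nM in this assay, at which 3 of the 3 values shown sit.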